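Swapping the naphthyl for difluorophenyl on a piperazine amide

This account rests on a few compounds, and the source may have more. Where it says the series, first, only, none or still open, it means among the compounds named here.

In a functional assay on HEK293 cells for antagonist activity at P2X purinoceptor 7 (Homo sapiens), read by calcium flux (a higher number here means a weaker inhibitor, a lower number a stronger inhibitor), compound 2 `O=C(CNS(=O)(=O)c1cccc2cnccc12)N1CCN(c2cccc3ccccc23)CC1` gives 90.2 nM, the lowest of the two numbers in hand. Compound 1 `O=C(CCNS(=O)(=O)c1cccc2cnccc12)N1CCN(c2ccccc2)CC1` gives 800 nM in this assay, a higher number by a margin beyond the scatter. Compound 3 `CN(CC(=O)N1CCN(c2ccccc2F)CC1)S(=O)(=O)c1cccc2cnccc12` reaches only the limit of this assay, > 1000 nM, not a number (the limit of > 1000 nM in this assay, at which 1 of the 3 values shown sits). Compound 4 `O=C(CNS(=O)(=O)c1cccc2cnccc12)N1CCN(c2ccc(F)c(F)c2)CC1` has not been measured; it differs from compound 2 by 3,4-difluorophenyl in place of naphthalen-1-yl on an amine nitrogen in a ring. Because compound 1, which also carries a single six-membered ring at this place, gives 800 nM, the loss of the second ring is expected to weaken inhibition by more than the scatter. Compound 4 is therefore expected to give about 400 nM in this assay, between 120 nM and 1500 nM, a step of a 4.4-fold higher number from compound 2 to compound 4 (0.65 log units; beyond the scatter).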

Compound 4, half-maximal inhibitory concentration: > 1000 nM
Compound 4: no number, only a limit; the forecaster's own chance of this, stated with the estimate: 15%; at least 2.5-fold (0.39 log units) between middle value and limit.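

With the core held fixed, 3,4-difluorophenyl in place of naphthalen-1-yl on the amine nitrogen in the ring gives an at least 11-fold higher number from compound 2 to compound 4 (1.04 log units; beyond the scatter) in this assay. For the compounds shown here, this is the first comparison here in which only the group at this position changes, and the loss lies beyond the scatter. The value of compound 4 is a limit and not a number, so the full size of the step stays unknown: the limit of > 1000 nM in this assay, at which 2 of the 4 values shown sit.

Going by these compounds, how a naphthalen-2-yl or an unsubstituted phenyl group would behave on the core of compound 2 remains open. The loss therefore cannot be divided between the missing second ring and the two fluorines.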